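Fluoro for Methyl on Compound 2

A few compounds are considered here, and "the series" means these few. Any claim that something is new, unique, unknown or untested is made for them only; others in the source may bear on it.

Of the compounds shown here, two have been measured so far in a functional assay on the whole organism with Mus musculus as the target; a lower number here means that less compound is needed, a higher number that more compound is needed for the effect. There, compound 1 `C[C@@H](NCc1ccc(CNc2ccccc2)cc1)C(N)=O` gives 119 mg/kg, and compound 2 `CNC(=O)[C@@H](CO)NCc1ccc(OCc2cccc(C)c2)cc1` gives 41.3 mg/kg. Compound 2 therefore holds the lower of the two numbers, and the gap between them lies beyond the usual scatter of repeated measurements. The two structures differ in more than one place, so this gap cannot be tied to any single change.

Compound 3 `CNC(=O)[C@@H](CO)NCc1ccc(OCc2cccc(F)c2)cc1` has not yet been measured in this assay. It differs from compound 2 in one place only: fluoro in place of methyl on an aromatic carbon. This is fluoro in place of methyl on an aromatic carbon, meta to a large group, so that 3-methylbenzyl becomes 3-fluorobenzyl. Among the measured compounds shown here, no measured pair shows what this exchange does, so the expectation rests only on how little of the structure changes. The expected change is a 1.3-fold lower number from compound 2 to compound 3 (0.11 log units; within the scatter), a modest move to a lower number that would stay within the scatter. Compound 3 is estimated at 32 mg/kg, with an expected range from 13 mg/kg to 80 mg/kg.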

Compound 3, dose for half-maximal effect: 25.1 mg/kg
Beside the measured number, compound 3's estimate is 1.3-fold (0.11 log units) above it; the range from low to high includes it.
By their numbers in this assay, from the lowest: compounds 3 and 2 (each within the scatter of the next); then compound 1.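

Among the compounds shown here, this is the first pair that differs in one place only, so a single exchange can finally be read on its own. In this assay, replacing 3-methylbenzyl with 3-fluorobenzyl gives a 1.6-fold lower number from compound 2 to compound 3 (0.22 log units; within the scatter) and so does not separate fluoro from methyl at this position, meta to a large group, where either can stand on the aromatic carbon without a step beyond the scatter. No measured property of these compounds bears on this result, and a whole-organism dose alone cannot show what lies behind it.

From the compounds shown here alone, two small groups at a single place say little about the range this position can accept, so it remains open whether a bare hydrogen, a chloro, a methoxy, a trifluoromethyl, a nitrile, an amine or a carboxylic acid would leave the number within the scatter or move it clearly beyond. Also open, going by these compounds, is whether the same exchange would read alike at another place on this ring, or on a different core such as that of compound 1.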